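Pyrrolidin-1-yl in Place of Dimethylamino on a Shared Core

The source may hold more compounds than are shown below. What is called first, only, known or untested is meant among the compounds shown, and "the series" means these compounds.

Compound 1 `CCN(CC)CC(=O)Nc1ccc(Nc2nc3cc(OC)ccc3cc2-c2ccc(OC)cc2)cc1`: 14000 nM
Compound 2 `COc1ccc(-c2cc3cc(OC)ccc3nc2Nc2ccc(NC(=O)CN(C)C)cc2)cc1`: 22200 nM

In a functional assay on HUVEC cells (Homo sapiens) for antiproliferative activity, read by MTT assay, with a stated time of 48 h (on this read-out lower numbers stand for stronger inhibition and higher numbers for weaker inhibition), compound 2 gives 22200 nM. Its nearest neighbour is compound 1, whose number lies within the scatter of it, so the two compounds cannot be told apart on this read-out. Compound 3 `COc1ccc(-c2cc3cc(OC)ccc3nc2Nc2ccc(NC(=O)CN3CCCC3)cc2)cc1` differs from compound 2 by pyrrolidin-1-yl in place of dimethylamino on a saturated chain carbon bound to a carbonyl carbon. For the measured compounds named here, no measured pair shows this change, so the step is expected to be small and without a clear direction: a 1.2-fold lower number from compound 2 to compound 3 (0.09 log units; within the scatter). Compound 3 is therefore estimated at 18000 nM, within a range from 7000 nM to 50000 nM.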

Compound 3, half-maximal inhibitory concentration: 13100 nM
The estimate for compound 3 lay 1.4-fold (0.14 log units) above the measured number; the measured number falls inside the stated range.
By their numbers in this assay, from the lowest: compounds 3, 1 and 2 (each within the scatter of the next).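

In this assay, for the compounds shown here, pyrrolidin-1-yl in place of dimethylamino on a saturated chain carbon bound to a carbonyl carbon gives a 1.7-fold lower number from compound 2 to compound 3 (0.23 log units; within the scatter) and this is the first measured pair for that change. This position thus carries one five-membered non-aromatic ring in place of the open dimethylamino group, and the read-out does not tell compound 2 and compound 3 apart. It remains a single pair on one core.

On these data alone, whether a piperidine ring, a morpholine ring or a longer chain ending in an amine would also stay within the scatter remains open. Nothing at hand gives a cause for this result.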